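Leaving the 3,4-dihydroxyphenyl group behind

This account rests on a few compounds, and the source may have more. Where it says the series, first, only, none or still open, it means among the compounds named here.

In a functional assay on KBVIN cells (Homo sapiens) for antiproliferative activity, read by sulforhodamine B assay, with a stated time of 3 days (a higher number here means that more compound is needed for the effect, a lower number that less compound is needed), compound 2 (`CCC1=C(O)c2c(oc(-c3ccc(O)c(O)c3)cc2=O)C(CC)(CC)C1=O`) gives 5.41 uM, the higher of the two numbers, while compound 1 (`CCC1=C(O)c2c(oc(-c3ccc(C(C)C)cc3)cc2=O)C(CC)(CC)C1=O`) gives 1.08 uM. Compound 3 (`CCC1=C(O)c2c(oc(-c3cccc(C)c3C)cc2=O)C(CC)(CC)C1=O`) carries 2,3-dimethylphenyl in place of 3,4-dihydroxyphenyl on an aromatic carbon. Going by the values given here, one measured step bears on this change, a 5.0-fold higher number from compound 1 to compound 2 (0.70 log units; beyond the scatter), which brought the 3,4-dihydroxyphenyl in. Compound 3 lacks that group too, so a step of similar or somewhat smaller size towards a lower number is expected. The expected step is a 2.7-fold lower number from compound 2 to compound 3 (0.43 log units; beyond the scatter). Compound 3 is estimated at 2 uM, with a range from 0.8 uM to 5.5 uM.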

Compound 3, concentration for half-maximal effect: 0.85 uM
Beside the measured number, compound 3's estimate is 2.4-fold (0.37 log units) above it; low and high end bracket the measured number.
By their numbers in this assay, from the lowest: compounds 3 and 1 (each within the scatter of the next); then compound 2.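

In this assay, going by these compounds alone, replacing the 3,4-dihydroxyphenyl group with 2,3-dimethylphenyl gives a 6.4-fold lower number from compound 2 to compound 3 (0.80 log units; beyond the scatter) and so shows that 4-isopropylphenyl is not the only group at this position to stand clear of compound 2. The comparison of the two groups without hydroxyl substituents gives a 1.3-fold lower number from compound 1 to compound 3 (0.10 log units; within the scatter) and does not separate them, although their carbon substituents differ in name and placement. Nothing available explains the difference from compound 2.

The compounds shown leave open whether one hydroxyl group alone would match compound 2, and where a phenyl ring bearing an amine or a carboxylic acid would fall.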